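Replacing the Chlorine of Compound 1 with a Larger Group

The compounds below may be only part of what the source reports. "The series", "measured", "known", "first", "only" and "open" are said of these compounds alone.

Three compounds share one core and differ only in the halogenated phenyl group attached to the double-bonded chain. Compound 1 `O=C(CCl)Nc1ccc(C(=O)/C=C/c2ccc(Br)cc2)cc1` carries a 4-bromophenyl group, compound 2 `O=C(CCl)Nc1ccc(C(=O)/C=C/c2ccc(F)cc2)cc1` a 4-fluorophenyl group and compound 3 `O=C(CCl)Nc1ccc(C(=O)/C=C/c2cccc(Cl)c2)cc1` a 3-chlorophenyl group. In a functional assay on MCF7 cells (Homo sapiens) for cytotoxicity, read by MTT assay, with a stated time of 72 h (on this read-out lower numbers stand for stronger inhibition and higher numbers for weaker inhibition), compound 1 gives 4640 nM, compound 2 gives 5470 nM and compound 3 gives 5340 nM. Compound 1 thus holds the lowest of the three numbers, yet a 1.2-fold higher number from compound 1 to compound 2 (0.07 log units; within the scatter) and a 1.2-fold higher number from compound 1 to compound 3 (0.06 log units; within the scatter) both lie within the scatter, as does a 1.0-fold lower number from compound 2 to compound 3 (0.01 log units; within the scatter), so the three compounds are not separated by these measurements.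

Compound 4 `O=C(CSC(=S)N[C@H]1CCOC1=O)Nc1ccc(C(=O)/C=C/c2ccc(Br)cc2)cc1` departs from compound 1 at a different place: a group of 10 heavy atoms (5 carbon, 1 nitrogen, 2 oxygen, 2 sulfur; one five-membered non-aromatic ring with 1 hetero atom) in place of one chlorine atom, on a saturated chain carbon bound to a carbonyl carbon. None of the three measured steps touches this place; each of them exchanges one halogenated phenyl group for another and each falls within the scatter. Going by the values given here, the measurements therefore contain no step that bears on the change from compound 1 to compound 4, and any expectation rests on compound 1 alone. Compound 4 is expected to give about 3500 nM in this assay, with a range from 800 nM to 15000 nM, which amounts to an expected 1.3-fold lower number from compound 1 to compound 4 (0.12 log units; within the scatter).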

Compound 4, half-maximal inhibitory concentration: 18700 nM
Compound 4: middle estimate off by 5.3-fold (0.73 log units), on the low side, outside the stated range (above it).
By their numbers in this assay, from the lowest: compounds 1, 3 and 2 (each within the scatter of the next); then compound 4.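

The saturated chain carbon bound to a carbonyl carbon is the only place in this set where a change separates two compounds in this assay: the group of 10 heavy atoms in place of one chlorine atom gives a 4.0-fold higher number from compound 1 to compound 4 (0.61 log units; beyond the scatter), whereas each exchange of one halogenated phenyl group for another stayed within the scatter. On this read-out the higher number stands for weaker inhibition, so with the 4-bromophenyl group held constant, this replacement of the chlorine atom weakens inhibition, though the finding rests on this single pair. Nothing measured here bears on why the number rises at this place.

The compounds shown leave open which part of the entering group goes with the step, whether the five-membered non-aromatic ring, the two sulfur atoms or the defined stereocentre. They also leave open how a simpler group at the same place, such as an amine, a methylthio group or a carboxylic acid, would compare with the chlorine atom of compound 1, and whether the same replacement would give a similar step alongside the 4-fluorophenyl group of compound 2 or the 3-chlorophenyl group of compound 3.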